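The source may hold more compounds than are shown below. What is called first, only, known or untested is meant among the compounds shown, and "the series" means these compounds.

Compound 1 `COC(=O)/C(=C/c1ccccc1)CN1C(=O)[C@@H](OC)[C@H]1c1ccc(F)cc1`: 21800 nM
Compound 2 `COC(=O)/C(=C/c1ccccc1)CN1C(=O)[C@@H](OC)[C@H]1c1ccc(OC)cc1`: 14000 nM
Compound 3 `COC(=O)/C(=C/c1ccccc1)CN1C(=O)[C@@H](OC)[C@H]1c1ccccc1`: 11100 nM

In a functional assay on MDA-MB-231 cells (Homo sapiens) for antiproliferative activity, read by MTT assay, with a stated time of 48 h (a higher number here means a weaker inhibitor, a lower number a stronger inhibitor), compound 3, at 11100 nM, stands within the scatter of the other two compounds. The measured steps to it are a 2.0-fold lower number from compound 1 to compound 3 (0.29 log units; within the scatter) and a 1.3-fold lower number from compound 2 to compound 3 (0.10 log units; within the scatter). Compound 4 `COC(=O)/C(=C/c1ccccc1)CN1C(=O)[C@@H](OC)[C@H]1c1cccc([N+](=O)[O-])c1` carries nitro in place of hydrogen on an aromatic carbon, meta to a large group: nitro in place of hydrogen on an aromatic carbon. Among the measured compounds shown here, no nitro compound has been measured, so the closest evidence is the other exchanges on an aromatic carbon, including a 1.6-fold lower number from compound 1 to compound 2 (0.19 log units; within the scatter). None of these exceeds the scatter. In this assay, no step beyond the scatter is therefore expected, and neither direction is favoured. The expected step is a 1.3-fold higher number from compound 3 to compound 4 (0.10 log units; within the scatter). For compound 4 the estimated value is 14000 nM, with an expected range of 6000 nM to 32000 nM.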

Compound 4, half-maximal inhibitory concentration: 14400 nM
For compound 4 the middle estimate is 1.0-fold (0.01 log units) below the measured one, within the range that was stated.
By their numbers in this assay, from the lowest: compounds 3, 2, 4 and 1 (each within the scatter of the next).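

In this assay, placing nitro on an aromatic carbon, meta to a large group, gives a 1.3-fold higher number from compound 3 to compound 4 (0.11 log units; within the scatter) and so adds a group of three heavy atoms to this ring without moving the number beyond the scatter. Set against the two other substituted rings, phenyl bearing nitro gives a 1.0-fold higher number from compound 2 to compound 4 (0.01 log units; within the scatter) and a 1.5-fold lower number from compound 1 to compound 4 (0.18 log units; within the scatter), and both steps also lie within the scatter. No measurement at hand explains why this position responds so little.

The compounds shown leave open whether an amine or a carboxylic acid on this ring would produce a step beyond the scatter.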